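Dropping the Fluorine from Compound 2 to Compound 3

The compounds below may be only part of what the source reports. "The series", "measured", "known", "first", "only" and "open" are said of these compounds alone.

Compound 1 `Cc1ccc(N2CCN(C(=O)c3oc(C)nc3-c3ccccc3)CC2)c(C)c1` and compound 2 `COc1cccc(N2CCN(C(=O)c3oc(C)nc3-c3ccc(F)cc3)CC2)c1` share one core and differ elsewhere. In a functional assay on HL-60 cells (Homo sapiens) for inhibition, read by MTT assay, with a stated time of 72 h (a higher number here means a weaker inhibitor, a lower number a stronger inhibitor), compound 1 gives 101 nM, while compound 2 gives 112 nM, the higher of the two numbers, though its gap to compound 1 lies within the scatter. Compound 3 `COc1cccc(N2CCN(C(=O)c3oc(C)nc3-c3ccccc3)CC2)c1` has not yet been measured. It differs from compound 2 by hydrogen in place of fluoro on an aromatic carbon. Going by the values given here, no step between measured compounds shows what such a change does here, so the expected step of a 1.1-fold lower number from compound 2 to compound 3 (0.03 log units; within the scatter) is one of no size beyond the scatter. Compound 3 is therefore estimated at 105 nM, with a range from 50 nM to 220 nM.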

Compound 3, half-maximal inhibitory concentration: 34.8 nM
Beside the measured number, compound 3's estimate is 3.0-fold (0.48 log units) above it; measured number below the stated range.
By their numbers in this assay, from the lowest: compound 3; then compounds 1 and 2 (each within the scatter of the next).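

In this assay the change from 4-fluorophenyl to phenyl gives a 3.2-fold lower number from compound 2 to compound 3 (0.51 log units; beyond the scatter) and so shows that this position, para to a large group, responds to losing the fluoro. With 3-methoxyphenyl in place of 2,4-dimethylphenyl on an amine nitrogen in a ring, the phenyl series gives a 2.9-fold lower number from compound 1 to compound 3 (0.46 log units; beyond the scatter) even though compound 1 and compound 2 stood within the scatter of each other. Nothing available here explains either step. From the compounds shown here alone, whether a chloro, methyl or nitrile group at this position would act like fluoro or like hydrogen stays open. So does whether the fluoro-to-hydrogen step holds with 2,4-dimethylphenyl on the amine nitrogen.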